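The compounds below may be only part of what the source reports. "The series", "measured", "known", "first", "only" and "open" are said of these compounds alone.

Working notes on the series. Compound 2 `O=C1C(=O)N(CCCCn2cc(COc3cc(=O)oc4ccccc34)nn2)c2ccccc21` gives 72% in a functional assay on HCT-116 cells (Homo sapiens) for inhibition, read by sulforhodamine B assay, with a stated time of 48 h, tested at 50 uM; a lower number here means less inhibition of growth, a higher number more inhibition of growth at the concentration tested. Compound 1 `COc1ccc2c(c1)C(=O)C(=O)N2CCCCn1cc(COc2cc(=O)oc3ccccc23)nn1` carries one change relative to compound 2, (methoxy in place of hydrogen on an aromatic carbon), and in this assay compound 1 gives 48%; the step is a number 24 percentage points lower from compound 2 to compound 1 (beyond the scatter). Compound 3 `O=C1C(=O)N(CCCCCn2cc(COc3cc(=O)oc4ccccc34)nn2)c2ccccc21` has a core that differs from that of compound 2; the difference between the two cores is not broken down here. In this assay compound 3 gives 65%, and the values of compound 2 and compound 3 lie within the scatter of each other.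

Compound 4 `COc1ccc2c(c1)C(=O)C(=O)N2CCCCCn1cc(COc2cc(=O)oc3ccccc23)nn1` has not yet been measured. For the measured compounds named here, it stands to compound 3 as compound 1 stands to compound 2: the change methoxy in place of hydrogen on an aromatic carbon is the same change, at the same place, as the one made from compound 2 to compound 1. Going by the values given here, the expected step is a number 23 percentage points lower from compound 3 to compound 4 (beyond the scatter), a loss of similar size, because the one measured precedent is a number 24 percentage points lower from compound 2 to compound 1 (beyond the scatter). With a single precedent the range is kept wide. For compound 4 in this assay a value of 42% is expected, between 28% and 56%.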

Compound 4, percent growth inhibition at one concentration: 25%
Compound 4: middle estimate off by 17 percentage points, on the high side; measured number below the stated range.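

In this assay, methoxy in place of hydrogen on an aromatic carbon lowers the number on both cores, and the new step is a number 40 percentage points lower from compound 3 to compound 4 (beyond the scatter) on the core of compound 3. For the compounds shown here, what this does not show is how the change would behave on any further core, or which part of the difference between the two cores goes with the difference in size, as the series holds only two such pairs. The direction of the step carries from one core to the other in these two pairs, but its size does not carry, so the step on one core gives only a loose guide to the step on the other: the same change on two cores in this assay, a number 24 percentage points lower (beyond the scatter) from compound 2 to compound 1 and a number 40 percentage points lower (beyond the scatter) from compound 3 to compound 4, 16 percentage points apart, beyond the scatter of two such steps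

From the compounds shown here alone, whether a hydroxy group or a chlorine atom in place of the methoxy on the same aromatic carbon brings a loss of the same kind stays open. Also open, going by these compounds, is how the methoxy step runs on a core with a longer chain.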